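Shortening the hydroxamate chain by one carbon

The source may report more compounds than this note shows. Statements on the series, on what has been measured and on what is new or still open speak of the compounds shown alone.

Measured so far:
compound 1 `Nc1ncnc2c1c(-c1cnc3[nH]ccc3c1)nn2CCCC(=O)NO` gives > 50000 nM
compound 2 `Nc1nc2cc(-c3nn(CCCCCCCCCC(=O)NO)c4ncnc(N)c34)ccc2o1` gives 28600 nM

In a functional assay on HepG2 cells (Homo sapiens) for inhibition, read by MTT assay, with a stated time of 72 h (a lower number here means a stronger inhibitor, a higher number a weaker inhibitor), compound 1 gives > 50000 nM, which is a limit of the assay rather than a number. Going by the values given here, compound 2 gives 28600 nM in this assay, the only number among the two values shown. Compound 3 `Nc1nc2cc(-c3nn(CCCCCCCCC(=O)NO)c4ncnc(N)c34)ccc2o1` differs from compound 2 in one place: hydroxycarbamoyl in place of (hydroxycarbamoyl)methyl on a saturated chain carbon, eight bonds along the chain from an aromatic nitrogen. Among the compounds with values here, no measured pair shows the effect of this change, so nothing points to a step beyond the usual scatter in either direction. For compound 3 the estimated value is 30000 nM, with a range from 10000 nM to 80000 nM. The expected step of a 1.0-fold higher number from compound 2 to compound 3 (0.02 log units; within the scatter) is essentially none.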

Compound 3, half-maximal inhibitory concentration: 2610 nM
Compound 3: the middle estimate sits 11-fold (1.06 log units) above what was measured, and the stated range ends above it.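

Removing one carbon from the chain gives an 11-fold lower number from compound 2 to compound 3 (1.04 log units; beyond the scatter) in this assay, so this position is sensitive to chain length, with hydroxycarbamoyl in place of (hydroxycarbamoyl)methyl making a large difference. Going by these compounds alone, this is the first measured pair that isolates a single change, since compound 1 differs from compound 2 in more than one place. Nothing measured here explains why the step is so large.

A single pair cannot show whether the number keeps falling as the chain shortens. It also leaves open whether a still shorter chain would do better, or whether a carboxylic acid could replace hydroxycarbamoyl at the chain end.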